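The source may hold more compounds than are shown below. What is called first, only, known or untested is meant among the compounds shown, and "the series" means these compounds.

Working notes on the series. Among the measured compounds shown here, compound 1 `CCN(Cc1cccs1)C(=O)C(C)Oc1ccc(C)cc1` gives 889 nM in an assay on HEK293 cells for agonist activity at transient receptor potential cation channel subfamily M member 8 (Homo sapiens), read by fluorescence and calcium flux, with a stated time of 15 min (a lower number here means that less compound is needed, a higher number that more compound is needed for the effect), the second highest of the three numbers measured so far. Compound 2 `Cc1ccc(OCC(=O)N(Cc2cccs2)c2ncccn2)cc1` gives 3700 nM in this assay, a higher number than compound 1 by a margin beyond the scatter, while compound 3 `O=C(COc1ccc2c(c1)CCC2)N(Cc1cccs1)c1ccn[nH]1` gives 0.001 nM in this assay, a far lower number. For the measured compounds named here, no pair of measured compounds differing in one place is available to anchor a step. Compound 4 `CCN(Cc1cccs1)C(=O)C(C)(C)Oc1ccc(C)cc1` is not yet measured and differs from compound 1 by methyl in place of hydrogen on a saturated chain carbon bound to a carbonyl carbon, an oxygen on an aromatic ring and a saturated chain carbon. Without precedent in the set, a small step is expected, within the scatter or a modest move toward a higher number, a 1.3-fold higher number from compound 1 to compound 4 (0.13 log units; within the scatter). Compound 4 is thus estimated at 1200 nM in this assay, within a range of 400 nM to 4000 nM.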

Compound 4, half-maximal effective concentration: 11000 nM
The estimate for compound 4 lay 9.2-fold (0.96 log units) below the measured number; the measured number lies above the stated range.
By their numbers in this assay, from the lowest: compound 3; then compound 1; then compound 2; then compound 4.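

Among the compounds shown here, the first single-place change falls on this carbon: in this assay, methyl in place of hydrogen gives a large move toward a higher number, a 12-fold higher number from compound 1 to compound 4 (1.09 log units; beyond the scatter). A single added methyl at this saturated chain carbon is thus enough to shift the value well beyond the scatter. Nothing at hand bears on the reason for this step.

Open, on these data alone, is how an ethyl or a hydroxyl group at this carbon would read. Also open, as far as these compounds go, is whether the added methyl would give a similar step on the cores of compound 2 and compound 3.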